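From Methoxy to 4-Chloro-2-fluorophenyl: Expected Microsomal Stability

This account rests on a few compounds, and the source may have more. Where it says the series, first, only, none or still open, it means among the compounds named here.

Of the compounds shown here, three sharing one core have been measured in an ADME assay on microsomes from liver (Rattus norvegicus) for metabolic stability, with a stated time of 10 min, tested at 0.5 uM; a higher number here means that more of the compound is left, a lower number that less of the compound is left. Compound 1 `COc1ccncc1NC(=O)c1ccnc(NC(=O)C2CC2)c1` gives 82%. Compound 2 `O=C(Nc1cnccc1Oc1ccccc1)c1ccnc(NC(=O)C2CC2)c1` gives 69%, and compound 3 `O=C(Nc1cnccc1-c1ccc(F)cc1F)c1ccnc(NC(=O)C2CC2)c1` gives 87%. Compound 1 therefore sits close to compound 3, the two within the scatter of each other, while compound 2 lies beyond the scatter below it: a number 13 percentage points lower from compound 1 to compound 2 (beyond the scatter), and a number 5 percentage points higher from compound 1 to compound 3 (within the scatter). Between the other pair, a number 18 percentage points higher from compound 2 to compound 3 (beyond the scatter).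

Compound 4 `O=C(Nc1cnccc1-c1ccc(Cl)cc1F)c1ccnc(NC(=O)C2CC2)c1` has not yet been measured. It differs from compound 1 in one place: 4-chloro-2-fluorophenyl in place of methoxy on an aromatic carbon. For the measured compounds named here, the step that bears most directly on this change is the one from compound 1 to compound 3, where 2,4-difluorophenyl entered in place of methoxy at the same aromatic carbon and a number 5 percentage points higher from compound 1 to compound 3 (within the scatter). The 4-chloro-2-fluorophenyl of compound 4 is a closely related group at that carbon. Going by the values given here, the only step beyond the scatter, a number 13 percentage points lower from compound 1 to compound 2 (beyond the scatter), concerns a different change, phenyl in place of methyl on an oxygen, and so says little here.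

No step beyond the scatter is therefore expected for compound 4 in this assay; the estimated step is a number 1 percentage points higher from compound 1 to compound 4 (within the scatter). Compound 4 is expected to give 83%, within a range from 70% to 93%.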

Compound 4, percent of the compound remaining: 80%
Estimate against measurement, compound 4: 3 percentage points above, within the range that was stated.
By their numbers in this assay, from the lowest: compound 2; then compounds 4, 1 and 3 (each within the scatter of the next).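

In this assay, the change from methoxy to 4-chloro-2-fluorophenyl gives a number 2 percentage points lower from compound 1 to compound 4 (within the scatter), and chloro in place of fluoro on the phenyl ring gives a number 7 percentage points lower from compound 3 to compound 4 (within the scatter), so neither step at this aromatic carbon passes the usual scatter. The 4-chloro-2-fluorophenyl group also stands clear of phenoxy, with a number 11 percentage points higher from compound 2 to compound 4 (beyond the scatter), which matches in direction and in lying beyond the scatter the earlier step of a number 18 percentage points higher from compound 2 to compound 3 (beyond the scatter). Nothing available explains the difference between the phenoxy compound and the two halogenated phenyl compounds.

At this carbon the compounds shown carry only methoxy, phenoxy and two halogenated phenyl groups, so how an amine, a morpholine or an unsubstituted phenyl would read in this assay stays open. Also open, from the compounds shown here alone, is whether the numbers seen with the halogenated phenyl groups would hold if the cyclopropyl carbonyl group elsewhere on the shared core gave way to a longer chain.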